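Adding a Methyl to the Pyrimidine Ring of Compound 3

The source may hold more compounds than are shown below. What is called first, only, known or untested is meant among the compounds shown, and "the series" means these compounds.

Three thiourea compounds sharing one core have been measured in a functional assay on LoVo cells (Homo sapiens) for antiproliferative activity, read by sulforhodamine B assay, with a stated time of 48 h; on this read-out higher numbers stand for weaker inhibition and lower numbers for stronger inhibition. Compound 1 `NS(=O)(=O)c1ccc(N/C(S)=N\c2ccnc3cc(C(F)(F)F)ccc23)cc1` gives 34500 nM. Compound 2 `N=C(N)NS(=O)(=O)c1ccc(N/C(S)=N\c2ccnc3cc(C(F)(F)F)ccc23)cc1` gives 23900 nM. Compound 3 `O=S(=O)(Nc1ncccn1)c1ccc(N/C(S)=N\c2ccnc3cc(C(F)(F)F)ccc23)cc1` gives 34700 nM. On these numbers compound 3 has the highest value of the three, yet the steps of a 1.0-fold higher number from compound 1 to compound 3 (0.00 log units; within the scatter) and a 1.5-fold higher number from compound 2 to compound 3 (0.16 log units; within the scatter) both lie within the scatter, so no real separation among the three can be claimed, and the step of a 1.4-fold lower number from compound 1 to compound 2 (0.16 log units; within the scatter) points the same way.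

Compound 4 `Cc1ccnc(NS(=O)(=O)c2ccc(N/C(S)=N\c3ccnc4cc(C(F)(F)F)ccc34)cc2)n1` differs from compound 3 by methyl in place of hydrogen on an aromatic carbon. Among the measured compounds shown here, none of the measured steps touches this pyrimidine ring; all three alter what sits on the sulfonamide nitrogen, and each of them stayed within the scatter. For the measured compounds named here, the only guidance is therefore that the measured alterations around this end of the molecule have left this assay essentially unchanged, and a single methyl on the ring is a smaller change than any of them.

For compound 4 the expected step is a 1.1-fold lower number from compound 3 to compound 4 (0.02 log units; within the scatter), a change not beyond the scatter. Compound 4 is thus estimated at 33000 nM, with a range from 15000 nM to 72000 nM.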

Compound 4, half-maximal inhibitory concentration: 31000 nM
Estimate against measurement, compound 4: 1.1-fold (0.03 log units) above; the range from low to high includes it.
By their numbers in this assay, from the lowest: compounds 2, 4, 1 and 3 (each within the scatter of the next).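

In this assay, among the compounds shown here, the step of a 1.1-fold lower number from compound 3 to compound 4 (0.05 log units; within the scatter) is the first reading from a change on the pyrimidine ring itself, since the earlier steps altered only what sits on the sulfonamide nitrogen, and this methyl, placed next to the ring nitrogen, stays within the scatter. The comparisons with the simpler sulfonamide-nitrogen groups agree: a 1.1-fold lower number from compound 1 to compound 4 (0.05 log units; within the scatter) and a 1.3-fold higher number from compound 2 to compound 4 (0.11 log units; within the scatter) are also within the scatter, so 4-methylpyrimidin-2-yl joins hydrogen, pyrimidin-2-yl and the group in compound 2 as a fourth substituent on that nitrogen with no real separation from the others. No supporting measurement is available to explain this flat result.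

On these data alone, a single methyl is only one small probe at one ring position, so it remains open whether an amine, a carboxylic acid or a longer chain such as butyl at this same place would shift the number beyond the scatter. As far as these compounds go, it is also open whether a change elsewhere on the shared core, rather than at this end of the molecule, would do so in this assay.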